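Hydrogen for methyl on an aromatic nitrogen

The source may report more compounds than this note shows. Statements on the series, on what has been measured and on what is new or still open speak of the compounds shown alone.

Measured so far:
compound 1 `COc1cccc(CNC(=O)c2nn(C)c3cc(-c4cn[nH]c4)ccc23)c1`: < 1 nM
compound 2 `COc1cccc(CNC(=O)c2cc3cc(-c4cn[nH]c4)ccc3[nH]2)c1`: 17 nM

In an assay on isolated protein for inhibition of Rho-associated protein kinase 2 (Homo sapiens), read by HTRF, with a stated time of 4 h (a higher number here means a weaker inhibitor, a lower number a stronger inhibitor), compound 1 gives < 1 nM, which is a limit of the assay and not a number. Compound 1 therefore sits at the limit of < 1 nM in this assay, at which 1 of the 2 values shown sits, so its place on the numbers is open-ended. Compound 2 gives 17 nM in this assay. Compound 3 `COc1cccc(CNC(=O)c2n[nH]c3cc(-c4cn[nH]c4)ccc23)c1` is not yet measured; it differs from compound 1 by hydrogen in place of methyl on an aromatic nitrogen. Among the measured compounds shown here, no measured pair isolates this change. A modest loss, at most slightly beyond the scatter, is expected in this assay. Compound 3 is expected at 1.5 nM (range 0.3 nM to 8 nM), an expected step of an at least 1.5-fold higher number from compound 1 to compound 3 (0.17 log units; that floor lies within the scatter).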

Compound 3, half-maximal inhibitory concentration: < 1 nM
Compound 3 ended at the assay's limit; the forecaster's own chance of this, stated with the estimate: 35%; at least 1.5-fold (0.17 log units) between middle value and limit.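

In this assay, compound 1 and compound 3 both end at the assay's limit, which is not a number, so no step can be read between them: the limit of < 1 nM in this assay, at which 2 of the 3 values shown sit. The compounds shown leave open how far methyl and hydrogen on that aromatic nitrogen differ, if at all.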